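This account rests on a few compounds, and the source may have more. Where it says the series, first, only, none or still open, it means among the compounds named here.

Three related compounds, each carrying a chloromethyl arm on a benzyl group attached to a shared core, have been tested so far. Compound 1 `ClCc1ccccc1Cn1cnc2c(Cl)ncnc21` gives 2700 nM in a functional assay on ACHN cells (Homo sapiens) for cytotoxicity, read by sulforhodamine B assay, with a stated time of 48 h; a higher number here means a weaker inhibitor of growth, a lower number a stronger inhibitor of growth. Compound 2 `ClCc1cccc(Cn2cnc3ncnc(Cl)c32)c1` gives 1860 nM in this assay, and compound 3 `ClCc1cccc(Cn2cnc3c(Cl)ncnc32)c1` gives 2080 nM in this assay. Among these three numbers compound 3 stands second highest; its nearest neighbour is compound 2, which differs from it by less than the usual scatter, and the furthest is compound 1, which also lies within that scatter. The three values therefore cannot be ranked with any confidence.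

Compound 4 `ClCc1cccc(Cn2cnc3c(Cl)nc(Cl)nc32)c1` has not yet been tested in this assay. It differs from compound 3 in one place: chloro in place of hydrogen on an aromatic carbon, sitting on an aromatic carbon of a six-membered aromatic ring with two nitrogens, between two ring nitrogen atoms, meta to a chloro group and to a fused ring, and para to a fused ring. For the measured compounds named here, no pair of measured compounds shows this same change, so no measured step can serve as a guide. Because compound 3 gives 2080 nM and compound 1 and compound 2 both lie within the scatter of that number, a step from compound 3 to compound 4 in this assay is expected to be modest, most likely no larger than the scatter, with no clear direction. Compound 4 is estimated at 1500 nM, with a range from 500 nM to 4500 nM. The expected step is a 1.4-fold lower number from compound 3 to compound 4 (0.14 log units; within the scatter).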

Compound 4, concentration for 50% growth inhibition: 1900 nM
Compound 4: middle estimate off by 1.3-fold (0.10 log units), on the low side, and the stated range covers the measured number.
By their numbers in this assay, from the lowest: compounds 2, 4, 3 and 1 (each within the scatter of the next).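

For the compounds shown here, the new step is the first direct look at this position, the aromatic carbon between two ring nitrogen atoms: in this assay, chloro in place of hydrogen there gives a step that lies within the scatter (a 1.1-fold lower number from compound 3 to compound 4 (0.04 log units; within the scatter)). The ring of the shared core can therefore carry this extra chloro group with no readable difference in growth inhibition, so the position accepts at least one added heavy atom in these cells. No supporting measurement is available to explain this outcome, whether from the compound's behaviour in the cells or from any other kind of test.

A single atom at a single position is a narrow test, and an amine, a methoxy group or a longer chain in the same place could give a quite different number. Going by these compounds, it also remains open whether the same chloro group would give a similar result on the isomers with the arrangements seen in compound 1 and compound 2.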